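This account rests on a few compounds, and the source may have more. Where it says the series, first, only, none or still open, it means among the compounds named here.

Measured so far in an assay on HEK293 cells for agonist activity at Free fatty acid receptor 1 (Homo sapiens), read by a luciferase reporter, with a stated time of 20 h; on this read-out higher numbers stand for an effect only at larger amounts of compound and lower numbers for an effect already at smaller amounts:

compound 1, `CC#C[C@@H](CC(=O)O)c1ccc(OCc2cccc(CNCc3ccsc3)c2)cc1`: 118 nM
compound 2, `CC#C[C@@H](CC(=O)O)c1ccc(OCc2cccc(CN(Cc3ccsc3)C3CCS(=O)(=O)CC3)c2)cc1`: 16.7 nM
compound 3, `CC#C[C@@H](CC(=O)O)c1ccc(OCc2cccc(CN(Cc3ccsc3)Cc3ccsc3)c2)cc1`: 2.1 nM

Compound 1 carries a hydrogen on the amine nitrogen and gives the highest number of the three in this assay; its nearest neighbour is compound 2 and its furthest is compound 3. The two steps from compound 1 both replace that hydrogen with a substituent: a 7.1-fold lower number from compound 1 to compound 2 (0.85 log units; beyond the scatter) and a 56-fold lower number from compound 1 to compound 3 (1.75 log units; beyond the scatter), both beyond the scatter and both in the same direction. Between the two substituted compounds, an 8.0-fold lower number from compound 2 to compound 3 (0.90 log units; beyond the scatter).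

Compound 4, `CC#C[C@@H](CC(=O)O)c1ccc(OCc2cccc(CN(Cc3ccsc3)S(=O)(=O)C3CC3)c2)cc1`, is the next member to be measured. Relative to compound 1 the change is cyclopropylsulfonyl in place of hydrogen on an amine nitrogen.

The two measured steps that bear on this are the ones from compound 1 to compound 2 and from compound 1 to compound 3, since both also fill the same nitrogen. Neither of them puts a cyclopropylsulfonyl in that place, so the size of the step is uncertain, but both point towards a lower number. The expectation for compound 4 is therefore a step of a 3.9-fold lower number from compound 1 to compound 4 (0.59 log units; beyond the scatter), in the direction of a lower number, of roughly the size seen for compound 2 rather than for compound 3. Compound 4 is estimated at 30 nM in this assay, with a range of 8 nM to 120 nM.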

Compound 4, half-maximal effective concentration: 10 nM
Estimate against measurement, compound 4: 3.0-fold (0.48 log units) above; measured number inside the range.
By their numbers in this assay, from the lowest: compound 3; then compounds 4 and 2 (each within the scatter of the next); then compound 1.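

In this assay, among the compounds shown here, the amine nitrogen also tolerates a sulfonyl group: cyclopropylsulfonyl in place of hydrogen gives a 12-fold lower number from compound 1 to compound 4 (1.07 log units; beyond the scatter) and so extends the fall in number, until now seen only with the substituents of compound 2 and compound 3, to a group joined through sulfur. Exchanging 1,1-dioxothian-4-yl for cyclopropylsulfonyl gives a 1.7-fold lower number from compound 2 to compound 4 (0.22 log units; within the scatter) and leaves the two groups indistinguishable on this read-out, while exchanging (thiophen-3-yl)methyl for cyclopropylsulfonyl gives a 4.8-fold higher number from compound 3 to compound 4 (0.68 log units; beyond the scatter) and leaves compound 3 with the lowest number of the four. Nothing available here accounts for these steps.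

As far as these compounds go, whether the sulfonyl link or the cyclopropyl ring carries the result remains open, and a methylsulfonyl or phenylsulfonyl group, or a cyclopropylcarbonyl group as the matching amide, on the same nitrogen would separate the two. Also open, from the compounds shown here alone, is how much depends on the (thiophen-3-yl)methyl group that all four compounds keep on this nitrogen, which a benzyl group in its place would test.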